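The compounds below may be only part of what the source reports. "The series", "measured", "known", "first", "only" and "open" are said of these compounds alone.

Measured in a functional assay on NCI-H1299 cells (Homo sapiens) for inhibition, read by scintillation counting, with a stated time of 30 min, tested at 30 uM; a lower number here means less inhibition, a higher number more inhibition at the concentration tested (going by the name of the read-out):
compound 1 `O=C(Oc1ccc(Cl)cc1OC(=O)c1ccccc1O)c1ccccc1O` gives 51.6%
compound 2 `COc1cc(C(=O)Oc2cccc(OC)c2OC(=O)c2cc(OC)c(OC)c(OC)c2)cc(OC)c1OC` gives 33.3%
compound 3 `COc1cc(C(=O)Oc2ccc(Cl)cc2OC(=O)c2cc(OC)c(OC)c(OC)c2)cc(OC)c1OC` gives 1.7%

Compound 2 stands second highest of the three in this assay. Compound 1 lies above it, by a gap beyond the usual scatter, and compound 3 lies furthest off, well below it, again beyond the scatter. Among the measured compounds shown here, no two of the measured compounds differ in only one place, so no single-change step is available as a yardstick.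

Compound 4 `COc1cc(C(=O)Oc2cccc(F)c2OC(=O)c2cc(OC)c(OC)c(OC)c2)cc(OC)c1OC` differs from compound 2 in one place: fluoro in place of methoxy on an aromatic carbon. The change sits on the central ring, ortho to a large group and meta to a large group.

For the measured compounds named here, with no comparable step in hand, the expectation in this assay for the step from compound 2 to compound 4 is a modest loss of inhibition, a number 9.3 percentage points lower from compound 2 to compound 4 (within the scatter), possibly not beyond the scatter. Compound 4 is estimated at 24%, with a range from 5% to 45%.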

Compound 4, a percentage reported as inhibition, at one concentration (the size of the read-out at that concentration, not a potency): 7.9%
For compound 4 the middle estimate is 16.1 percentage points above the measured one; measured number inside the range.
By their numbers in this assay, from the lowest: compounds 3 and 4 (each within the scatter of the next); then compound 2; then compound 1.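

In this assay, fluoro in place of methoxy on this aromatic carbon, ortho to a large group and meta to a large group, gives a number 25.4 percentage points lower from compound 2 to compound 4 (beyond the scatter). Among the compounds shown here, this is the first single-place step, and it shows that the position is sensitive to this change, with methoxy and fluoro not interchangeable here. Nothing measured in this set accounts for the size of the step.

Still open, from the compounds shown here alone, is whether an ethoxy group, a hydroxyl or an amine at this position would retain the inhibition of compound 2. A single step also leaves open whether the same change would have a similar effect in the other compounds.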